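Variation at the carbonyl carbon of a shared core

The source may report more compounds than this note shows. Statements on the series, on what has been measured and on what is new or still open speak of the compounds shown alone.

Measured so far:
- compound 1 `Cc1nc(S(C)(=O)=O)ccc1Oc1ncnc(OC2CCN(C(=O)OC(C)(C)CF)CC2)c1F` gives 19.9 nM in a functional assay on isolated protein for inhibition of Glucose-dependent insulinotropic receptor (Homo sapiens), read by HTRF and cAMP accumulation; a higher number here means that more compound is needed for the effect, a lower number that less compound is needed
- compound 2 `Cc1nc(S(C)(=O)=O)ccc1Oc1ncnc(OC2CCN(C(=O)OC3(C(F)(F)F)CCC3)CC2)c1F` gives 14.3 nM in this assay
- compound 3 `Cc1nc(S(C)(=O)=O)ccc1Oc1ncnc(OC2CCN(C(=O)SC3(C)CC3)CC2)c1F` gives 13.2 nM in this assay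

Compound 2 holds the second highest of the three numbers. Its nearest neighbour is compound 3, with a 1.1-fold lower number from compound 2 to compound 3 (0.03 log units; within the scatter); its furthest is compound 1, with a 1.4-fold lower number from compound 1 to compound 2 (0.14 log units; within the scatter). All three measured compounds therefore sit within the scatter of one another.

The next compound, compound 4 `CCC(F)(F)C(=O)N1CCC(Oc2ncnc(Oc3ccc(S(C)(=O)=O)nc3C)c2F)CC1`, differs from compound 2 at one place:
a group of 5 heavy atoms (3 carbon, 2 fluorine; no ring) in place of a group of 9 heavy atoms (5 carbon, 1 oxygen, 3 fluorine; one four-membered non-aromatic ring of carbon only), on a carbonyl carbon

Within the data shown here, every measured step so far touches the same region. Exchanging groups on the carbonyl carbon gave a 1.5-fold lower number from compound 1 to compound 3 (0.18 log units; within the scatter) and a 1.1-fold lower number from compound 2 to compound 3 (0.03 log units; within the scatter), and exchanging the group on an oxygen next to a carbonyl group gave a 1.4-fold lower number from compound 1 to compound 2 (0.14 log units; within the scatter). None of these moved the number beyond the scatter, whether the entering group carried a ring, a sulfur, or fluorine atoms. The change to 1,1-difluoropropyl on the carbonyl carbon is of the same kind, so no step beyond the scatter is expected: the estimated step is a 1.1-fold higher number from compound 2 to compound 4 (0.05 log units; within the scatter).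

For compound 4 the expected value in this assay is 16 nM, with a range from 7 nM to 36 nM.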

Compound 4, half-maximal effective concentration: 17.4 nM
Estimate against measurement, compound 4: 1.1-fold (0.04 log units) below; low and high end bracket the measured number.
By their numbers in this assay, from the lowest: compounds 3, 2, 4 and 1 (each within the scatter of the next).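

In this assay, compounds 1, 2 and 3 all carry an oxygen or a sulfur on the carbonyl carbon, whereas compound 4 has 1,1-difluoropropyl there, which places a carbon on it and brings no ring and no hydrogen-bond acceptor. This change still leaves the number within the scatter of all three earlier compounds, with a 1.2-fold higher number from compound 2 to compound 4 (0.09 log units; within the scatter), a 1.3-fold higher number from compound 3 to compound 4 (0.12 log units; within the scatter) and a 1.1-fold lower number from compound 1 to compound 4 (0.06 log units; within the scatter), so among these four compounds neither the oxygen or sulfur on the carbonyl carbon nor a ring in the group is required to keep the number in this range, and none of the four goes against that reading. No measured evidence is available to explain this result.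

From the compounds shown here alone, whether an amine, a carboxylic acid or a longer chain on the carbonyl carbon would also stay within the scatter remains open, as does whether any group at this place can move the number beyond it. The shared core is the same in all four compounds, so the effect of changes elsewhere on it cannot be read from this set.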